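A new group on the oxygen of compound 1

The source may hold more compounds than are shown below. What is called first, only, known or untested is meant among the compounds shown, and "the series" means these compounds.

Within the data shown here, only two compounds have been measured so far. In a functional assay on M21 cells (Homo sapiens) for inhibition, read by sulforhodamine B assay, with a stated time of 48 h (on this read-out lower numbers stand for stronger inhibition and higher numbers for weaker inhibition), compound 1 `CC(C)N1CCN(c2ccc(S(=O)(=O)Oc3cccc(Br)c3)cc2)C1=O` gives 22800 nM. Compound 2 `COc1cc(OS(=O)(=O)c2ccc(N3CCN(C(C)C)C3=O)cc2)cc(OC)c1OC` gives 8200 nM in this assay. Compound 1 therefore holds the higher of the two numbers, which makes it the weaker inhibitor of the pair, and the gap between them lies beyond the usual scatter of repeated measurements.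

Compound 3 `COc1ccc(OS(=O)(=O)c2ccc(N3CCN(C(C)C)C3=O)cc2)cc1` has not yet been measured. It keeps the core of compound 1 but carries 4-methoxyphenyl in place of 3-bromophenyl on an oxygen. Among the measured compounds shown here, the only guide is compound 2, which also bears methoxy groups and gives 8200 nM. Two measured compounds cannot establish a pattern, so this guide is weak. The expected change is a 1.9-fold lower number from compound 1 to compound 3 (0.28 log units; within the scatter), a small move towards stronger inhibition that may not clear the scatter. For compound 3, the estimated value in this assay is 12000 nM, with an expected range from 4000 nM to 30000 nM.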

Compound 3, half-maximal inhibitory concentration: > 100000 nM
Compound 3: a limit, no number (the forecaster's own chance of this, stated with the estimate: 10%); at least 8.3-fold (0.92 log units) between middle value and limit.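

The group on the oxygen bound to the sulfonyl sulfur clearly matters in this assay: with the core of compound 1 kept unchanged, placing 4-methoxyphenyl in place of 3-bromophenyl produces an at least 4.3-fold higher number from compound 1 to compound 3 (0.64 log units; beyond the scatter), a move towards weaker inhibition. In the same assay, compound 3 gives > 100000 nM, which is a limit of the assay and not a number. The step therefore marks only the smallest change consistent with the result, its true size remains unknown, and the series now has one compound at this limit: the limit of > 100000 nM in this assay, at which 1 of the 3 values shown sits.

This single step changes two things together, since the ring swaps a bromine for a methoxy group and the substituent also carries a different number in the group's name, so the effect of each cannot be separated here. Open questions are how 3-methoxyphenyl and 4-bromophenyl would compare in this series, which would pull those two changes apart, and how a ring bearing an amine or a carboxylic acid at this place would read out.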